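Opening the Saturated Ring: a Forecast for Compound 3

A few compounds are considered here, and "the series" means these few. Any claim that something is new, unique, unknown or untested is made for them only; others in the source may bear on it.

In a functional assay on A549 cells (Homo sapiens) for antiproliferative activity, read by MTT assay, with a stated time of 72 h (a lower number here means a stronger inhibitor, a higher number a weaker inhibitor), compound 2 `O=C(Nc1ccc(CN2CCCC2)cc1)Nc1ccc2ncnc(Nc3cccc(C(F)(F)F)c3)c2c1` gives 830 nM, and compound 1 `O=C(Nc1ccc(CN2CCCCC2)cc1)Nc1ccc2ncnc(Nc3cccc(C(F)(F)F)c3)c2c1` gives 1050 nM, a gap within the scatter, so the two stand together. Among the compounds with values here, the single measured step, a 1.3-fold lower number from compound 1 to compound 2 (0.10 log units; within the scatter), exchanged one saturated ring for another at the same place. Compound 3 `CCN(CC)Cc1ccc(NC(=O)Nc2ccc3ncnc(Nc4cccc(C(F)(F)F)c4)c3c2)cc1` carries a different change: diethylamino in place of pyrrolidin-1-yl on a saturated chain carbon bound to an aromatic carbon. That earlier step bears on it only loosely, as it resized a ring whereas this change removes the ring altogether; it was within the scatter, and no move beyond the scatter is expected here. Compound 3 is expected at 830 nM, with a range from 450 nM to 1600 nM. The expected step is no change at the digits printed from compound 2 to compound 3 (within the scatter).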

Compound 3, half-maximal inhibitory concentration: 2070 nM
Compound 3: the middle estimate sits 2.5-fold (0.40 log units) below what was measured, and the stated range ends below it.
By their numbers in this assay, from the lowest: compounds 2, 1 and 3 (each within the scatter of the next, the first and the last beyond it).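

Opening the ring at this place, with the same count of heavy atoms, can matter: in this assay, the swap of pyrrolidin-1-yl for diethylamino gives a 2.5-fold higher number from compound 2 to compound 3 (0.40 log units; beyond the scatter). Within the data shown here, this is the first step here to pass beyond the scatter, and it is modest. Among these compounds, the matching swap from piperidin-1-yl gives a 2.0-fold higher number from compound 1 to compound 3 (0.29 log units; within the scatter), so the ring-opened compound is separated from only one of the two ring compounds, and nothing available explains the difference.

Still open, on these data alone, is where a smaller open-chain amine such as dimethylamino, or a ring holding oxygen such as morpholin-4-yl, would fall.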